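Amide removal at the aryl amine of compound 2

The source may report more compounds than this note shows. Statements on the series, on what has been measured and on what is new or still open speak of the compounds shown alone.

Two compounds carry numbers in a functional assay on CCRF-CEM cells (Homo sapiens) for inhibition, read by cell counting, with a stated time of 3 days (on this read-out lower numbers stand for stronger inhibition and higher numbers for weaker inhibition), so far. Compound 1 `COc1ccc(-c2nn3cc(-c4cccc(N)c4)nc3s2)cc1OC` gives 14000 nM in this assay. Compound 2 `C=C(Br)C(=O)Nc1cccc(-c2cn3nc(-c4cccc(OC)c4)sc3n2)c1` gives 1200 nM in this assay, the lowest of the two numbers, and the gap to compound 1 lies beyond the scatter. Compound 2 and compound 1 differ in more than one place, so nothing is counted for that pair; only their two values stand side by side.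

Compound 3 `COc1cccc(-c2nn3cc(-c4cccc(N)c4)nc3s2)c1` has not been measured. Relative to compound 2 the change is hydrogen in place of (1-bromoethenyl)carbonyl on a nitrogen on an aromatic ring. The product is a free amino group on the same shared core as compound 2, and in that respect compound 3 resembles compound 1, which also bears a free amino group and gives 14000 nM in this assay.

Within the data shown here, no measured step of this kind exists. Among the measured compounds shown here, with compound 1 as the only guide, the step from compound 2 to compound 3 is expected to be an 8.3-fold higher number from compound 2 to compound 3 (0.92 log units; beyond the scatter), a rise in the number well beyond the scatter. Compound 3 is therefore estimated at 10000 nM in this assay, within a range from 3000 nM to 40000 nM.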

Compound 3, half-maximal inhibitory concentration: > 250000 nM
Compound 3 was reported as a limit; the forecaster's own chance of this, stated with the estimate: 15%; middle value at least 25-fold (1.39 log units) away from the limit.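

Hydrogen in place of (1-bromoethenyl)carbonyl on a nitrogen on an aromatic ring gives the first one-place comparison in the series: in this assay it produces an at least 200-fold higher number from compound 2 to compound 3 (2.31 log units; beyond the scatter), so the group on this nitrogen carries a large share of the activity seen for compound 2. The reading for compound 3 is a limit of the assay and not a number: the limit of > 250000 nM in this assay, at which 1 of the 3 values shown sits. With the free amino group common to both compounds, hydrogen in place of methoxy on an aromatic carbon also gives a large step, an at least 17-fold higher number from compound 1 to compound 3 (1.25 log units; beyond the scatter), so the free amino group alone does not set the level in this assay.

Compound 2 is the only acylated member shown, so an acetyl group or a propenoyl group without bromine on the same nitrogen would be needed to separate the part played by the carbonyl from that of the bromoethenyl end. Whether the methoxy step holds with the (1-bromoethenyl)carbonyl group in place also remains open, as no such pair is among these three compounds.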